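This account rests on a few compounds, and the source may have more. Where it says the series, first, only, none or still open, it means among the compounds named here.

Compound 1 `CN(Cc1ccc2nccn2c1)c1nnc(-c2ccc(C3CC3)cc2)o1` carries a cyclopropyl on the shared core. In an assay on isolated protein for inhibition of tyrosine-protein kinase Mer (Homo sapiens), read by LC-MS (a higher number here means a weaker inhibitor, a lower number a stronger inhibitor), compound 1 gives 794 nM, the highest number among the three measured compounds. Compound 2 `CN(Cc1ccc2nccn2c1)c1nnc(-c2ccc(-c3ccccc3F)cc2)o1` gives 15.9 nM, and compound 3 `Cc1ncccc1-c1ccc(-c2nnc(N(C)Cc3ccc4nccn4c3)o2)cc1` gives 50.1 nM.

Compound 4 `Cc1noc(C)c1-c1ccc(-c2nnc(N(C)Cc3ccc4nccn4c3)o2)cc1` is not yet measured. It differs from compound 1 in one place: 3,5-dimethyl-1,2-oxazol-4-yl in place of cyclopropyl on an aromatic carbon. Among the compounds with values here, two measured steps bear on this change, both starting from compound 1 and both placing a ring on the same aromatic carbon: a 50-fold lower number from compound 1 to compound 2 (1.70 log units; beyond the scatter), and a 16-fold lower number from compound 1 to compound 3 (1.20 log units; beyond the scatter). Between those two aromatic replacements there is a 3.2-fold higher number from compound 2 to compound 3 (0.50 log units; beyond the scatter), so the size of the gain varies with the ring that enters. The 3,5-dimethyl-1,2-oxazol-4-yl is a five-membered aromatic ring bearing two methyl groups, and no five-membered aromatic replacement at this position has been measured, so the outcome is less certain than for the two six-membered rings.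

A step to a lower number beyond the scatter is nonetheless expected in this assay, since both measured aromatic replacements gave one, though smaller than either. For compound 4 the expected value is 100 nM, with a likely range from 30 nM to 320 nM. This estimate corresponds to an expected step of a 7.9-fold lower number from compound 1 to compound 4 (0.90 log units; beyond the scatter).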

Compound 4, half-maximal inhibitory concentration: 200 nM
The estimate for compound 4 lay 2.0-fold (0.30 log units) below the measured number; the range from low to high includes it.
By their numbers in this assay, from the lowest: compound 2; then compound 3; then compound 4; then compound 1.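

In this assay a five-membered aromatic ring with 2 hetero atoms also gives a lower number than cyclopropyl on this aromatic carbon, with a 4.0-fold lower number from compound 1 to compound 4 (0.60 log units; beyond the scatter) for the 3,5-dimethyl-1,2-oxazol-4-yl, so the gain is not confined to the six-membered rings of compound 2 and compound 3. The same group falls short of both six-membered rings, with a 4.0-fold higher number from compound 3 to compound 4 (0.60 log units; beyond the scatter) against the 2-methylpyridin-3-yl and a 13-fold higher number from compound 2 to compound 4 (1.10 log units; beyond the scatter) against the 2-fluorophenyl, and every gap among the four compounds lies beyond the scatter. This position therefore separates the aromatic replacements from one another as well as from cyclopropyl, and the spread among them is wider than compound 2 and compound 3 alone indicated.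

Ring size, hetero atoms and substituents all change together in these compounds, so the smaller gain of compound 4 cannot be assigned to any one of them. As far as these compounds go, an unsubstituted phenyl, a 1,2-oxazol-4-yl without its methyl groups, or an amine such as piperidine on the same carbon remain open questions for this position.

No measurement at hand speaks to what lies behind these differences.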